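Furan-2-yl in place of pyridin-3-yl on the amide carbonyl

The source may report more compounds than this note shows. Statements on the series, on what has been measured and on what is new or still open speak of the compounds shown alone.

Compound 1 `COc1cccc(C(=O)Nc2ccc(Cl)cc2CN2C(=O)c3ccccc3C2=O)c1`: 1500 nM
Compound 2 `O=C(Nc1ccc(F)cc1CN1C(=O)c2ccccc2C1=O)c1ccccn1`: 1500 nM
Compound 3 `O=C(Nc1ccc(Cl)cc1CN1C(=O)c2ccccc2C1=O)c1cccnc1`: 35000 nM

In an assay on CHO cells for positive allosteric modulation of metabotropic glutamate receptor 5 (Homo sapiens), read by FLIPR (a lower number here means that less compound is needed, a higher number that more compound is needed for the effect), compound 3 stands at the top of the three numbers. Its nearest neighbour is compound 1, and the only step that links two of these compounds by a single change is a 23-fold higher number from compound 1 to compound 3 (1.37 log units; beyond the scatter), a large move in the unfavourable direction. Compound 2, which carries a different halogen as well as a different ring, gives the same number as compound 1, so the two cannot be ranked against each other.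

Compound 4 `O=C(Nc1ccc(Cl)cc1CN1C(=O)c2ccccc2C1=O)c1ccco1` has not been measured. It differs from compound 3 by furan-2-yl in place of pyridin-3-yl on a carbonyl carbon. Among the compounds with values here, no measured pair shows this exact exchange, so the expectation rests on the single large step from compound 1 to compound 3 and on the fact that compound 1 and compound 2, which carry rings other than pyridin-3-yl on that carbonyl, both sit far lower than compound 3. A step downward is therefore expected, but its size is uncertain. Compound 4 is estimated at 8000 nM in this assay, with a range of 2500 nM to 30000 nM. That estimate corresponds to an expected step of a 4.4-fold lower number from compound 3 to compound 4 (0.64 log units; beyond the scatter).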

Compound 4, half-maximal effective concentration: 2300 nM
Estimate against measurement, compound 4: 3.5-fold (0.54 log units) above, and the stated range ends above it.
By their numbers in this assay, from the lowest: compounds 1, 2 and 4 (each within the scatter of the next); then compound 3.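

In this assay, furan-2-yl in place of pyridin-3-yl on the carbonyl carbon gives a 15-fold lower number from compound 3 to compound 4 (1.18 log units; beyond the scatter) and so undoes most of the earlier loss seen in a 23-fold higher number from compound 1 to compound 3 (1.37 log units; beyond the scatter) on the same core. With a 1.5-fold higher number from compound 1 to compound 4 (0.19 log units; within the scatter) as the remaining comparison, furan-2-yl and 3-methoxyphenyl cannot be told apart at this position, which shows that a five-membered aromatic ring with one hetero atom can stand here in place of the larger aryl group, and that of these three groups pyridin-3-yl alone gives a number beyond the scatter of the others. Pyridin-3-yl and furan-2-yl each count one hydrogen-bond acceptor and no donor, and nothing measured here explains why they part so widely in this assay.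

The compounds shown leave open whether the response at this position would hold with thiophene-2-yl, furan-3-yl or a saturated ring such as tetrahydrofuran-2-yl on the carbonyl. They also leave open what a methyl group, an amine or a carboxylic acid carried on the furan-2-yl ring would do to the number.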